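The source may hold more compounds than are shown below. What is called first, only, known or untested is meant among the compounds shown, and "the series" means these compounds.

Compound 1 `Cc1nn(C)c2c1C(c1ccccc1)=NCCN2` and compound 2 `Cc1nn(C)c2c1C(c1cccc(Cl)c1)=NCCN2` share one core and differ only by hydrogen in place of chloro on an aromatic carbon. In a functional assay on the whole organism for positive allosteric modulation, with Rattus norvegicus as the target (a lower number here means that less compound is needed, a higher number that more compound is needed for the effect), compound 2 gives 0.63 mg/kg, while compound 1 gives 2.5 mg/kg, which is the step of a 4.0-fold higher number from compound 2 to compound 1 (0.60 log units; beyond the scatter). Compound 3 `Cc1nn(C)c2c1C(c1cccc(Cl)c1)=NCCN2CCCN(C)C` differs from compound 2 by 3-(dimethylamino)propyl in place of hydrogen on a nitrogen on an aromatic ring in a ring. In this assay compound 3 reaches only a limit of the assay, > 10 mg/kg, the limit given as the limit of > 10 mg/kg in this assay, at which 1 of the 3 values shown sits. The step of an at least 15-fold higher number from compound 2 to compound 3 (1.20 log units; beyond the scatter) is therefore a lower bound. Compound 4 `Cc1nn(C)c2c1C(c1ccccc1)=NCCN2CCCN(C)C` differs from compound 3 by hydrogen in place of chloro on an aromatic carbon, the same change that turns compound 2 into compound 1. Compound 4 is expected to give about 40 mg/kg in this assay, an expected step that the limit leaves unreadable from compound 3 to compound 4. This expectation rests on the step of a 4.0-fold higher number from compound 2 to compound 1 (0.60 log units; beyond the scatter) seen for compound 1, and on compound 3 already standing at a limit, so compound 4 will most likely also return only a limit.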

Compound 4, minimum effective dose: > 10 mg/kg
Compound 4: no number, only a limit; the forecaster's own chance of this, stated with the estimate: 90%; the middle value does not contradict the limit.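

Putting 3-(dimethylamino)propyl on the ring nitrogen raises the dose needed on the phenyl core as well, with an at least 4.0-fold higher number from compound 1 to compound 4 (0.60 log units; beyond the scatter). The change therefore points the same way on the 3-chlorophenyl and phenyl cores, but each size is only a lower bound, so equal and different effects both remain possible: the same change on two cores in this assay, an at least 15-fold higher number (1.20 log units; beyond the scatter) from compound 2 to compound 3 and an at least 4.0-fold higher number (0.60 log units; beyond the scatter) from compound 1 to compound 4; the limit leaves it open whether they differ The step between compound 3 and compound 4 cannot be read, so it is not shown whether swapping chloro for hydrogen still matters once this chain is present.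

The compounds shown leave open whether a methyl or a shorter chain on that nitrogen would keep the effect. They also leave open what a carboxylic acid in place of the dimethylamino end would do.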